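A few compounds are considered here, and "the series" means these few. Any claim that something is new, unique, unknown or untested is made for them only; others in the source may bear on it.

The series shares one core and varies it at a single position. In a functional assay on K562 cells (Homo sapiens) for inhibition, read by fluorescence, with a stated time of 72 h (on this read-out higher numbers stand for weaker inhibition of growth and lower numbers for stronger inhibition of growth), compound 2 `CCCCc1cc2nn(-c3ccccc3)cc2cn1` gives 6700 nM. Compound 3 `Cc1nc(-c2ccsc2)cc2nn(-c3ccccc3)cc12` gives 10000 nM in this assay, a number sitting within the usual scatter of the value of compound 2. Compound 1 `Cc1nc(CCO)cc2nn(-c3ccccc3)cc12` reaches only a limit in this assay, namely > 100000 nM. Going by the values given here, the one measured step in the set runs an at least 10-fold lower number from compound 1 to compound 3 (1.00 log units; beyond the scatter), thiophen-3-yl entering in place of 2-hydroxyethyl, and its size is bounded by the limit of > 100000 nM in this assay, at which 1 of the 3 values shown sits. Compound 4 `c1ccc(-c2cc3nn(-c4ccccc4)cc3cn2)cc1` carries the change (phenyl in place of butyl on an aromatic carbon). Among the compounds with values here, no measured step covers an exchange of butyl for phenyl. Within the data shown here, what the numbers do show is that the thiophen-3-yl of compound 3 and the butyl of compound 2 sit within the scatter of each other, so a ring in place of the chain has not yet been seen to move the number beyond the scatter. Compound 4 is therefore expected to show a step of a 1.1-fold lower number from compound 2 to compound 4 (0.05 log units; within the scatter) that remains within the scatter. Compound 4 is estimated at 6000 nM, in a range from 1500 nM to 25000 nM.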

Compound 4, concentration for 50% growth inhibition: 3400 nM
Compound 4: middle estimate off by 1.8-fold (0.25 log units), on the high side; the measured number falls inside the stated range.
By their numbers in this assay, from the lowest: compounds 4, 2 and 3 (each within the scatter of the next, the first and the last beyond it). At a limit, above all of these: compound 1.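

In this assay, phenyl in place of butyl on the aromatic carbon next to the ring nitrogen gives a 2.0-fold lower number from compound 2 to compound 4 (0.29 log units; within the scatter). The earlier compounds shown here offered only an indirect hint across structures differing in more than one place, whereas this pair shows directly that, on this core, this read-out does not tell an aromatic ring of six carbons from the four-carbon butyl chain at this position. Nothing given here accounts for the size of this step.

The compounds shown leave open whether an amine, a carboxylic acid or a chain longer than butyl at this position would shift the number beyond the scatter. They also leave open how 2-hydroxyethyl or thiophen-3-yl would read on the core shared by compound 2 and compound 4.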